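A few compounds are considered here, and "the series" means these few. Any claim that something is new, unique, unknown or untested is made for them only; others in the source may bear on it.

Measured so far: compound 1 `CCCSc1nc(Cl)c2c(n1)N(Cc1ccccc1)C(C(=O)N1CCN(C(=O)OC(C)(C)C)CC1)N2` gives 29000 nM; compound 2 `CCCSc1nc(Cl)c2c(n1)N(CC1CCCCC1)C(C(=O)N1CCN(C)CC1)N2` gives 13200 nM; compound 3 `CCCSc1nc(Cl)c2c(n1)N(Cc1ccccc1)C(C(=O)NCCC1=CCc3ccccc31)N2` gives 48800 nM, all in a functional assay on A549 cells (Homo sapiens) for antiproliferative activity, read by MTT assay, with a stated time of 72 h; on this read-out lower numbers stand for stronger inhibition and higher numbers for weaker inhibition.

Compound 2 stands at the lowest number of the three in this assay; compound 1 sits above it beyond the scatter, and compound 3 further still. Compound 4 `CCCSc1nc(Cl)c2c(n1)N(CCNC(=O)OC(C)(C)C)C(C(=O)N1CCN(C)CC1)N2` has not been measured. It differs from compound 2 by ((tert-butoxycarbonyl)amino)methyl in place of cyclohexyl on a saturated chain carbon bound to a nitrogen on an aromatic ring in a ring. Going by the values given here, no step between measured compounds that differ in one place is available, so this change has no anchor of its own; the other two compounds, which differ from compound 2 in more than one place, both give higher numbers. A modest rise in number is expected, with the expected step of a 1.9-fold higher number from compound 2 to compound 4 (0.28 log units; within the scatter) close to the edge of the scatter. For compound 4 the estimate in this assay is 25000 nM, with a range from 8000 nM to 80000 nM.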

Compound 4, half-maximal inhibitory concentration: 12400 nM
Compound 4: the middle estimate sits 2.0-fold (0.30 log units) above what was measured; the measured number falls inside the stated range.
By their numbers in this assay, from the lowest: compounds 4 and 2 (each within the scatter of the next); then compounds 1 and 3 (each within the scatter of the next).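

In this assay, going by these compounds alone, the change gives a 1.1-fold lower number from compound 2 to compound 4 (0.03 log units; within the scatter) and is the first one-place step. On the saturated chain carbon bound to a nitrogen on an aromatic ring in a ring, this single pair shows that ((tert-butoxycarbonyl)amino)methyl can replace cyclohexyl, an open chain with a hydrogen-bond donor for a carbon ring with none, without a difference beyond the scatter. No evidence at hand bears on this result.

Still open, going by these compounds, is whether a free amine or a carboxylic acid at the end of the 2-ethyl chain, or a longer chain, would also stay within the scatter of compound 2.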